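Working notes: aryl substituent changes on the shared core

The source may hold more compounds than are shown below. What is called first, only, known or untested is meant among the compounds shown, and "the series" means these compounds.

Measured so far:
compound 1, `ONc1ccc(CNc2cc(Br)cc3[nH]ncc23)cc1`: 6%
compound 2, `N#Cc1ccc(CNc2cc(Br)cc3[nH]ncc23)cc1`: 73%

In an assay for inhibition of Tryptophan 2,3-dioxygenase (Homo sapiens), with a stated time of 1 h, tested at 10 uM (a lower number here means less inhibition, a higher number more inhibition at the concentration tested (going by the name of the read-out)), compound 2 gives 73%, the highest of the two numbers; compound 1 gives 6%, and the step of a number 67 percentage points higher from compound 1 to compound 2 (beyond the scatter) is the only measured one. Compound 3, `NS(=O)(=O)c1ccc(CNc2cc(Br)cc3[nH]ncc23)cc1`, differs from compound 2 by sulfamoyl in place of cyano on an aromatic carbon. Going by the values given here, only the step from compound 1 to compound 2 bears on this change, at the same place on the ring, and it was large. A downward step a number 38 percentage points lower from compound 2 to compound 3 (beyond the scatter) is therefore expected, of uncertain size. Compound 3 is estimated at 35%, within 5% to 70%.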

Compound 3, a percentage reported as inhibition, at one concentration (the size of the read-out at that concentration, not a potency): 75%
For compound 3 the middle estimate is 40 percentage points below the measured one; measured number outside the range, above it.
By their numbers in this assay, from the lowest: compound 1; then compounds 2 and 3 (each within the scatter of the next).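

In this assay the change to sulfamoyl at this position, para to a large group, gives a number 2 percentage points higher from compound 2 to compound 3 (within the scatter) and so leaves the read-out level with cyano. The high read-out is therefore not confined to the nitrile: two groups with different counts of heavy atoms and hydrogen-bond donors both stand well clear of hydroxyamino, with a number 69 percentage points higher from compound 1 to compound 3 (beyond the scatter) alongside the earlier step. Nothing available explains this result.

On these data alone, whether a carboxylic acid, an amine or a methyl sulfone at this place would hold the read-out stays open.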